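A few compounds are considered here, and "the series" means these few. Any claim that something is new, unique, unknown or untested is made for them only; others in the source may bear on it.

Compound 1 `Cc1cccc(NNC(=O)c2ccc(NS(=O)(=O)c3cnc(O)nc3O)cc2)c1` is assessed in a functional assay on OVCAR-3 cells (Homo sapiens) for antiproliferative activity, read by MTT assay, with a stated time of 24 h; on this read-out higher numbers stand for weaker inhibition and lower numbers for stronger inhibition. In this assay compound 1 gives only a limit, > 20000 nM. Compound 2 `Cc1ccccc1NNC(=O)c1cccc(NS(=O)(=O)c2cnc(O)nc2O)c1` likewise gives only a limit in this assay, > 20000 nM. Among the compounds with values here, compound 1 thus stands at the limit of > 20000 nM in this assay, at which 2 of the 2 values shown sit, and no step between the two measured compounds is known. Compound 3 `O=C(NNC(=O)c1ccccc1F)c1ccc(NS(=O)(=O)c2cnc(O)nc2O)cc1` differs from compound 1 by (2-fluorophenyl)carbonyl in place of 3-methylphenyl on an amine nitrogen. Within the data shown here, with no measured step to lean on, and with compound 1 sitting at the limit of > 20000 nM in this assay, at which 2 of the 2 values shown sit, no step beyond the scatter is expected in this assay. Compound 3 is therefore estimated at 25000 nM, between 8000 nM and 80000 nM, the expected step being a step that the limit leaves unreadable from compound 1 to compound 3.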

Compound 3, half-maximal inhibitory concentration: 16000 nM
Estimate against measurement, compound 3: 1.6-fold (0.19 log units) above, within the range that was stated.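

In this assay, within the data shown here, compound 3 gives the only value shown that is a number and not a limit, so a reading at this place on the amine nitrogen is possible with (2-fluorophenyl)carbonyl in place of 3-methylphenyl. The change gives an at least 1.2-fold lower number from compound 1 to compound 3 (0.09 log units; that floor lies within the scatter). Its true size cannot be read, as compound 1 gives only a limit: the limit of > 20000 nM in this assay, at which 2 of the 3 values shown sit.

Going by these compounds, whether the carbonyl or the fluorine matters more stays open, as both enter together. Also open, on these data alone, is how a plain benzoyl or an acetyl group would read on this nitrogen.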